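Extending the dimethylamino terminus of compound 3 with a dimethylbenzyl

A few compounds are considered here, and "the series" means these few. Any claim that something is new, unique, unknown or untested is made for them only; others in the source may bear on it.

Of the compounds shown here, three have been measured in an assay on CHO cells for binding affinity to Substance-P receptor (Homo sapiens); a lower number here means a stronger inhibitor, a higher number a weaker inhibitor. Compound 1 `CCCCCN(CCCCC)C(=O)N1CCN(C(=O)N(c2ccccc2)c2ccccc2)[C@H](C(=O)NCC(=O)O)C1` gives 597 nM. Compound 2 `CCCCCN(CCCCC)C(=O)N1CCN(C(=O)N(c2ccccc2)c2ccccc2)[C@H](C(=O)NCCN(C)C)C1` gives 55 nM, and the step of an 11-fold lower number from compound 1 to compound 2 (1.04 log units; beyond the scatter) is the largest gain seen so far. Compound 3 `CCCCCN(CCCCC)C(=O)N1CCN(C(=O)N(c2ccccc2)c2ccccc2)[C@H](C(=O)N(C)CCN(C)C)C1` gives 930 nM; its number is the highest of the three, but the difference from compound 1 is within the scatter, a 1.6-fold higher number from compound 1 to compound 3 (0.19 log units; within the scatter), while against compound 2 it is clearly beyond it, a 17-fold higher number from compound 2 to compound 3 (1.23 log units; beyond the scatter).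

Compound 4 `CCCCCN(CCCCC)C(=O)N1CCN(C(=O)N(c2ccccc2)c2ccccc2)[C@H](C(=O)N(C)CCN(C)Cc2cc(C)cc(C)c2)C1` is the next member. The change from compound 3 is 3,5-dimethylphenyl in place of hydrogen on a saturated chain carbon bound to an amine nitrogen. Within the data shown here, none of the measured steps covers this kind of change: the two steps beyond the scatter concern the amide-type nitrogen and the replacement of carboxy by (dimethylamino)methyl, not the substituents on the amine nitrogen itself. Among the measured compounds shown here, there is therefore no direct precedent in this set, and the expectation rests only on the fact that the amine terminus of compound 2 and compound 3 is tolerated with small groups. A modest improvement is estimated, a 2.3-fold lower number from compound 3 to compound 4 (0.37 log units; beyond the scatter), but with wide uncertainty. Compound 4 is thus expected to give about 400 nM in this assay, with a range from 80 nM to 2000 nM.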

Compound 4, half-maximal inhibitory concentration: 200 nM
For compound 4 the middle estimate is 2.0-fold (0.30 log units) above the measured one; the range from low to high includes it.
By their numbers in this assay, from the lowest: compound 2; then compound 4; then compounds 1 and 3 (each within the scatter of the next).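

In this assay the amine terminus is not limited to small groups: replacing methyl with 3,5-dimethylbenzyl on the amine nitrogen gives a 4.7-fold lower number from compound 3 to compound 4 (0.67 log units; beyond the scatter), a step beyond the scatter. Among these compounds, the earlier steps concerned only the replacement of carboxy and the methyl on the amide-type nitrogen, so this is the first reading of a change on the amine nitrogen itself, and it shows that an added six-membered aromatic ring of carbon only can lower the number at this position, although this reading holds only with the methyl on the amide-type nitrogen in place. No measurement in hand accounts for the size of this gain.

Still open, on these data alone, is whether the gain comes from the aromatic ring or from its two methyl groups, a question that an unsubstituted benzyl or a cyclohexylmethyl on the same amine nitrogen would help to settle. Also open, as far as these compounds go, is whether the 3,5-dimethylbenzyl gives a similar step when the amide-type nitrogen carries hydrogen, as it does in compound 2.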